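The source may report more compounds than this note shows. Statements on the series, on what has been measured and on what is new or still open speak of the compounds shown alone.

Compound 1 `O=C1COc2ccc(-c3cnc4ccccc4c3)cc2N1c1ccccc1`: > 40000 nM
Compound 2 `COc1ccc(N2C(=O)COc3ccc(-c4ccc(O)cc4)cc32)cc1`: 16400 nM

In a functional assay on HeLa cells (Homo sapiens) for antiproliferative activity, read by MTT assay, with a stated time of 72 h (on this read-out higher numbers stand for weaker inhibition and lower numbers for stronger inhibition), compound 1 gives only a limit, > 40000 nM, and not a number. Among the compounds with values here, compound 2 gives 16400 nM in this assay; no step between compound 1 and compound 2 is counted here, and the two values show only that one sits at the boundary of what the test can report while the other is a measured number. Where compound 1 stands is thus fixed only by the limit of > 40000 nM in this assay, at which 1 of the 2 values shown sits. Compound 3 `O=C1COc2ccc(-c3cnc4ccccc4c3)cc2N1C1CCCCC1` is not yet measured. It differs from compound 1 in one place: cyclohexyl in place of phenyl on an amide-type nitrogen in a ring. Within the data shown here, with compound 1 sitting at the limit there is no measured step to lean on, so the change is expected to amount to an at least 1.3-fold lower number from compound 1 to compound 3 (0.12 log units; that floor lies within the scatter), most likely still within weak inhibition. Compound 3 is expected to give about 30000 nM in this assay, somewhere between 8000 nM and 100000 nM.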

Compound 3, half-maximal inhibitory concentration: 19700 nM
For compound 3 the middle estimate is 1.5-fold (0.18 log units) above the measured one; the measured number falls inside the stated range.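

In this assay compound 1 gives > 40000 nM, which is a limit and not a number. With cyclohexyl in place of phenyl on the amide-type nitrogen in a ring, the same core gives a measured value, with compound 3 at 19700 nM, so an aromatic ring is not needed at this position for a measurable effect. The change amounts to an at least 2.0-fold lower number from compound 1 to compound 3 (0.30 log units; that floor lies within the scatter), and since only the floor of this step is known, its true size stays open: the limit of > 40000 nM in this assay, at which 1 of the 3 values shown sits.

On these data alone, both groups compared here are six-membered rings of carbon, so the effect of a methyl group, a longer alkyl chain or a cyclohexyl ring carrying an amine at this nitrogen remains open. As far as these compounds go, whether the same swap would act alike on the core of compound 2 also remains open.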